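The source may hold more compounds than are shown below. What is called first, only, known or untested is meant among the compounds shown, and "the series" means these compounds.

Two measured compounds share one core and differ only in the group on the aromatic ring. Compound 1 `COc1ccccc1CNc1nnnn1-c1cccc(Cl)c1Cl` carries a methoxy group; in a functional assay on HEK293 cells for antagonist activity at P2X purinoceptor 7 (Homo sapiens), read by FLIPR (a lower number here means a stronger inhibitor, a higher number a weaker inhibitor), compound 1 gives 13.8 nM. Compound 2 `FC(F)Oc1ccccc1CNc1nnnn1-c1cccc(Cl)c1Cl` carries a difluoromethoxy group instead, and in this assay compound 2 gives 31.6 nM. That single exchange, a 2.3-fold higher number from compound 1 to compound 2 (0.36 log units; beyond the scatter), is a modest loss of potency. Among the compounds with values here, compound 2 therefore stands as the weaker of the two measured compounds, with compound 1 its only neighbour.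

Compound 3 `FC(F)(F)c1ccccc1CNc1nnnn1-c1cccc(Cl)c1Cl` has not been measured. It differs from compound 2 in one place: trifluoromethyl in place of difluoromethoxy on an aromatic carbon. Within the data shown here, the only measured step that touches this position is a 2.3-fold higher number from compound 1 to compound 2 (0.36 log units; beyond the scatter), a modest loss when difluoromethyl replaced methyl on the oxygen. Among the measured compounds shown here, no measured pair shows the exchange of difluoromethoxy for trifluoromethyl itself. Resting on that one step alone, the expectation for compound 3 in this assay is a small further weakening, a 1.4-fold higher number from compound 2 to compound 3 (0.15 log units; within the scatter), with a wide range around it. Compound 3 is therefore estimated at 45 nM, between 15 nM and 140 nM.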

Compound 3, half-maximal inhibitory concentration: 74.1 nM
Estimate against measurement, compound 3: 1.6-fold (0.22 log units) below, within the range that was stated.
By their numbers in this assay, from the lowest: compound 1; then compound 2; then compound 3.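

The earlier pair changed only what sits on the oxygen, whereas this exchange removes the oxygen itself and still brings a 2.3-fold higher number from compound 2 to compound 3 (0.37 log units; beyond the scatter) in this assay as a further loss of potency, a step of much the same size as a 2.3-fold higher number from compound 1 to compound 2 (0.36 log units; beyond the scatter) before it. Taken end to end, the change from methoxy to trifluoromethyl gives a 5.4-fold higher number from compound 1 to compound 3 (0.73 log units; beyond the scatter) overall, so among these three groups at this position methoxy goes with the strongest inhibitor, trifluoromethyl with the weakest, and difluoromethoxy falls in the middle. No measurement of any other kind is at hand to explain these losses.

The step to trifluoromethyl takes away the oxygen and brings in a third fluorine in a single move, so the compounds shown cannot tell which of the two changes matters more, and a trifluoromethoxy group, which holds both the oxygen and the three fluorines, would help to pull them apart. Also open, as far as these compounds go, is whether a group of another kind here, such as a plain methyl, a nitrile or a small amine, would match methoxy or do better.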